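Amide aryl swap on the thiazolidinedione naphthyl ether series

The source may report more compounds than this note shows. Statements on the series, on what has been measured and on what is new or still open speak of the compounds shown alone.

Measured so far:
- compound 1 `O=C(COc1ccc2cc(/C=C3/SC(=O)NC3=O)ccc2c1)Nc1cccc(F)n1` gives 7200 nM in an assay on isolated protein for inhibition of histone deacetylase 8 (Homo sapiens), with a stated time of 1 h; on this read-out higher numbers stand for weaker inhibition and lower numbers for stronger inhibition
- compound 2 `Cc1cc(NC(=O)COc2ccc3cc(/C=C4/SC(=O)NC4=O)ccc3c2)no1` gives only the limit > 50000 nM in this assay

Compound 2 stands at the weak end of the two values shown. Its result in this assay is a limit of the assay, not a number (the limit of > 50000 nM in this assay, at which 1 of the 2 values shown sits), so only a lower bound on its half-maximal inhibitory concentration is known. Going by the values given here, the one measured step leading to it, an at least 6.9-fold higher number from compound 1 to compound 2 (0.84 log units; beyond the scatter), already set compound 2 beyond the scatter from compound 1.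

Compound 3 `O=C(COc1ccc2cc(/C=C3/SC(=O)NC3=O)ccc2c1)Nc1ccc(Br)cc1` is not yet measured. Its change from compound 2 is 4-bromophenyl in place of 5-methyl-1,2-oxazol-3-yl on an amide-type nitrogen. Among the compounds with values here, the only step that bears on it is an at least 6.9-fold higher number from compound 1 to compound 2 (0.84 log units; beyond the scatter), which shows that replacing a six-membered aromatic amide substituent by the 5-methyl-1,2-oxazol-3-yl group cost at least a modest amount. Returning to a six-membered carbocyclic aryl on the amide-type nitrogen is therefore expected to move compound 3 back toward the region of compound 1, though the 4-bromophenyl group has not itself been tested in this series, so the expectation is loose.

For compound 3 the estimate in this assay is 12000 nM, within 3000 nM to 50000 nM. The step this estimate means is expected to be an at least 4.1-fold lower number from compound 2 to compound 3 (0.61 log units; beyond the scatter), a gain in inhibition from the limit, of uncertain size.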

Compound 3, half-maximal inhibitory concentration: 16000 nM
For compound 3 the middle estimate is 1.3-fold (0.12 log units) below the measured one, within the range that was stated.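

In this assay, the 4-bromophenyl group on the amide-type nitrogen gives a measurable half-maximal inhibitory concentration where 5-methyl-1,2-oxazol-3-yl did not, with an at least 3.1-fold lower number from compound 2 to compound 3 (0.49 log units; beyond the scatter). The size of that step is only a bound, as the result for compound 2 is a limit of the assay and not a number: the limit of > 50000 nM in this assay, at which 1 of the 3 values shown sits. A six-membered aromatic ring of carbon only does not fully match the 6-fluoropyridin-2-yl group, however, with a 2.2-fold higher number from compound 1 to compound 3 (0.35 log units; beyond the scatter), so among the three compounds the choice of six-membered aryl also moves the read-out, though by less than the bound on the change from the five-membered ring.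

The 4-bromophenyl and 6-fluoropyridin-2-yl groups differ in both ring atoms and halogen, and the compounds shown do not separate these two changes; an unsubstituted phenyl or an unsubstituted pyridin-2-yl group on the amide-type nitrogen would bear on that. Going by these compounds, whether the weak result of compound 2 belongs to five-membered aromatic rings in general or to 5-methyl-1,2-oxazol-3-yl alone also stays open, and a thiazol-2-yl group would test it.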